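A few compounds are considered here, and "the series" means these few. Any claim that something is new, unique, unknown or untested is made for them only; others in the source may bear on it.

Working notes on the series. Among the compounds with values here, in an ADME assay on WI-38 cells (Homo sapiens) for cytotoxicity, read by MTT assay, with a stated time of 72 h (on this read-out lower numbers stand for stronger inhibition and higher numbers for weaker inhibition), compound 1 `O=C(CCc1cccc2c1B(O)OC2)Nc1cccc(I)c1` gives 71000 nM and compound 2 `O=C(CCc1cccc2c1B(O)OC2)Nc1cccc(-c2ccc(F)cc2)c1` gives 4100 nM, the lower of the two numbers so far. The next structure is compound 3 `CSc1ccc(-c2cccc(NC(=O)CCc3cccc4c3B(O)OC4)c2)cc1`, which has methylsulfanyl in place of fluoro on an aromatic carbon, para to a large group: methylsulfanyl in place of fluoro on an aromatic carbon. Within the data shown here, only one measured step bears on this change: a 17-fold lower number from compound 1 to compound 2 (1.24 log units; beyond the scatter), a large step beyond the scatter, with 4-fluorophenyl in place of iodo. That step brought in the phenyl ring itself. Here the ring stays and only its substituent changes, and no measured pair tests such a change. No shift beyond the scatter is therefore expected in this assay. The expected step is a 1.0-fold lower number from compound 2 to compound 3 (0.01 log units; within the scatter). For compound 3 the estimated value is 4000 nM, with an expected range of 1500 nM to 11000 nM.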

Compound 3, half-maximal inhibitory concentration: 3800 nM
Estimate against measurement, compound 3: 1.1-fold (0.02 log units) above, within the range that was stated.
By their numbers in this assay, from the lowest: compounds 3 and 2 (each within the scatter of the next); then compound 1.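

Within the data shown here, at this place, para to a large group, methylsulfanyl in place of fluoro gives a 1.1-fold lower number from compound 2 to compound 3 (0.03 log units; within the scatter) in this assay, which is the first measured change of the ring substituent alone, and it stays within the scatter. With the 4-(methylsulfanyl)phenyl group in place of iodo, the step is a 19-fold lower number from compound 1 to compound 3 (1.27 log units; beyond the scatter), so the large step away from compound 1 is now seen with two different substituents on the added ring, not only with fluoro. No measurement in hand explains either step.

Going by these compounds, with only fluoro and methylsulfanyl at this place, the read-out for a very different substituent, such as an amine or a carboxylic acid, remains open. Also open, on these data alone, is whether a longer chain on the sulfur would stay within the scatter of compound 3.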